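This account rests on a few compounds, and the source may have more. Where it says the series, first, only, none or still open, it means among the compounds named here.

Working notes on the sulfonylpiperidine series. Compound 1 `Cc1c(C)c(S(=O)(=O)N2CCC(N3CCC(C)CC3)CC2)c(C)c2c1OC(C)(C)C2` gives 0.8 nM in a functional assay on HT-29 cells (Homo sapiens) for antiproliferative activity, read by CellTiter-Glo, with a stated time of 72 h; on this read-out higher numbers stand for weaker inhibition and lower numbers for stronger inhibition. Compound 2 `CC1CCN(C2CCN(S(=O)(=O)c3ccccc3Br)CC2)CC1` gives 3 nM in this assay. Compound 3 `Cc1nc(Cl)sc1S(=O)(=O)N1CCC(N2CCC(C)CC2)CC1` gives 1.5 nM in this assay, the second highest of the three numbers; its nearest neighbour is compound 1 and its furthest is compound 2, and both gaps sit within the scatter, so no order among the three can be read from them.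

Compound 4 `CC1CCN(C2CCN(S(=O)(=O)c3cccc(Br)c3)CC2)CC1` is not yet measured in this assay. It differs from compound 3 in one place: 3-bromophenyl in place of 2-chloro-4-methyl-1,3-thiazol-5-yl on a sulfonyl sulfur. Going by the values given here, one measured step bears on this position: a 2.0-fold lower number from compound 2 to compound 3 (0.30 log units; within the scatter), a change within the scatter when a 2-chloro-4-methyl-1,3-thiazol-5-yl took the place of a 2-bromophenyl. Among the compounds with values here, compound 4 carries a 3-bromophenyl, so compounds 2 and 4 share a bromophenyl on the sulfonyl sulfur, though no step between them is measured. Given that exchanging the whole group on the sulfonyl sulfur moved the number only within the scatter, the step is expected to be a 1.3-fold higher number from compound 3 to compound 4 (0.12 log units; within the scatter), no change beyond the scatter in either direction. Compound 4 is therefore estimated at 2 nM, with a range from 0.7 nM to 6 nM.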

Compound 4, half-maximal inhibitory concentration: 1.2 nM
Estimate against measurement, compound 4: 1.7-fold (0.22 log units) above; the range from low to high includes it.
By their numbers in this assay, from the lowest: compounds 1, 4, 3 and 2 (each within the scatter of the next, the first and the last beyond it).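

In this assay, a 3-bromophenyl on the sulfonyl sulfur in place of 2-chloro-4-methyl-1,3-thiazol-5-yl gives a 1.3-fold lower number from compound 3 to compound 4 (0.10 log units; within the scatter), so for this pair, a six-membered aromatic ring of carbon only and with 0 hydrogen-bond acceptors does as well as a five-membered aromatic ring with 2 hetero atoms and 2 hydrogen-bond acceptors. The exchange of 2-bromophenyl for 3-bromophenyl gives a 2.5-fold lower number from compound 2 to compound 4 (0.40 log units; beyond the scatter), a modest step but the only one listed that lies beyond the scatter, which shows that this position can tell apart two groups of the same composition, something the earlier step within the scatter could not show. Nothing in hand accounts for either step.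

The compounds shown leave open whether the bromine itself matters, since a plain phenyl or a phenyl carrying a carboxylic acid, an amine or a longer alkyl chain in its place does not appear among them. They also leave open whether the difference between the two bromophenyl compounds would hold with any other group on the ring.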